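Hydroxy in place of dimethylamino on the chain

This account rests on a few compounds, and the source may have more. Where it says the series, first, only, none or still open, it means among the compounds named here.

Compound 1 `Cn1c(Cc2nn(C)c(=O)c3ccccc23)nnc1SCCCCCCCC(=O)Nc1ccc(Cl)cc1Cl`: 3900 nM
Compound 2 `CN(C)CCCn1nc(Cc2nnc(SCCCCCCCC(=O)Nc3ccc(Cl)cc3Cl)n2C)c2ccccc2c1=O`: 3200 nM

In an assay on 32D cells for inhibition of interleukin-15 (Mus musculus), read by resazurin assay, with stated times of 30 min and 2.5 days, in the presence of a further agent that is not named here (on this read-out lower numbers stand for stronger inhibition and higher numbers for weaker inhibition), compound 2 stands with the lowest of the two numbers, and compound 1 sits within the scatter of it, as the step of a 1.2-fold lower number from compound 1 to compound 2 (0.09 log units; within the scatter) shows. Compound 3 `Cn1c(Cc2nn(CCCO)c(=O)c3ccccc23)nnc1SCCCCCCCC(=O)Nc1ccc(Cl)cc1Cl` differs from compound 2 by hydroxy in place of dimethylamino on a saturated chain carbon, three bonds along the chain from an aromatic nitrogen. Within the data shown here, no measured step changes this group directly; the only step on this chain, from compound 1 to compound 2, stayed within the scatter, so the step of a 1.1-fold higher number from compound 2 to compound 3 (0.04 log units; within the scatter) is expected to be none beyond the scatter. Compound 3 is therefore estimated at 3500 nM, between 1500 nM and 8000 nM.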

Compound 3, half-maximal inhibitory concentration: > 30000 nM
Compound 3 gave a limit, no number (the forecaster's own chance of this, stated with the estimate: 10%); middle value at least 8.5-fold (0.93 log units) away from the limit.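

In this assay compound 3 gives a limit and not a number: the limit of > 30000 nM in this assay, at which 1 of the 3 values shown sits.

Among these compounds, this shows that the group on the chain matters here, which the earlier compounds did not reveal. Hydroxy in place of dimethylamino gives an at least 9.3-fold higher number from compound 2 to compound 3 (0.97 log units; beyond the scatter), and the whole chain gives an at least 7.6-fold higher number from compound 1 to compound 3 (0.88 log units; beyond the scatter), while 3-(dimethylamino)propyl alone gave only a 1.2-fold lower number from compound 1 to compound 2 (0.09 log units; within the scatter).

The compounds shown leave open whether this step goes with losing dimethylamino or with gaining hydroxy. They also leave open how a primary amine, a methyl ether or a carboxylic acid would read in the same place.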